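Swapping the Benzyl Ether Substituent in a Urea Analogue

This account rests on a few compounds, and the source may have more. Where it says the series, first, only, none or still open, it means among the compounds named here.

Compound 3 `Cc1ccc(NC(=O)NC(=O)c2ccc(OCc3ccccc3F)cc2)cc1-c1nc2ccccc2[nH]1` has the lowest number of the three compounds measured in a functional assay on MNK45 cells (Homo sapiens) for inhibition, read by MTT assay, with a stated time of 48 h (on this read-out higher numbers stand for weaker inhibition and lower numbers for stronger inhibition), giving 1830 nM. Its nearest neighbour is compound 1 `Cc1ccc(NC(=S)NC(=O)c2ccc(OCc3ccccc3F)cc2)cc1-c1nc2ccccc2[nH]1`, which in this assay gives 2420 nM; these two values lie within the usual scatter, so neither can be called stronger. Compound 2 `Cc1ccc(NC(=S)NC(=O)c2ccc(OCc3ccc(Cl)c(Cl)c3)cc2)cc1-c1nc2ccccc2[nH]1` in this assay gives 8410 nM, which lies beyond the scatter from compound 3.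

Compound 4 `Cc1ccc(NC(=O)NC(=O)c2ccc(OCc3ccc(Cl)c(Cl)c3)cc2)cc1-c1nc2ccccc2[nH]1` has not yet been measured. It differs from compound 3 in a single place: 3,4-dichlorophenyl in place of 2-fluorophenyl on a saturated chain carbon bound to an oxygen on an aromatic ring. The same exchange has been seen once among the measured compounds, where it produced a 3.5-fold higher number from compound 1 to compound 2 (0.54 log units; beyond the scatter). Within the data shown here, compounds 1 and 2 differ from compounds 3 and 4 elsewhere in the shared core, and no measured step shows whether that part of the structure changes the outcome of the exchange, so the one observed step is the only guide.

Among the measured compounds shown here, for compound 4 the expected step is a 3.4-fold higher number from compound 3 to compound 4 (0.53 log units; beyond the scatter), upward in number, because the single comparable measurement was a 3.5-fold higher number from compound 1 to compound 2 (0.54 log units; beyond the scatter). Compound 4 is therefore estimated to give 6200 nM in this assay, with a plausible range from 2500 nM to 15000 nM.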

Compound 4, half-maximal inhibitory concentration: 5820 nM
Beside the measured number, compound 4's estimate is 1.1-fold (0.03 log units) above it, within the range that was stated.
By their numbers in this assay, from the lowest: compounds 3 and 1 (each within the scatter of the next); then compounds 4 and 2 (each within the scatter of the next).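

In this assay, among these compounds, putting 3,4-dichlorophenyl in place of 2-fluorophenyl gives a 3.2-fold higher number from compound 3 to compound 4 (0.50 log units; beyond the scatter), so a change earlier seen on only one core has now been read on a second. The core of compound 1 carries a thiocarbonyl where the core of compound 3 carries a carbonyl, and this is the only difference between the two cores. On the evidence of these two pairs, that difference does not alter the outcome of the exchange, which raises the number by a similar amount on both cores: the same change on two cores in this assay, a 3.5-fold higher number (0.54 log units; beyond the scatter) from compound 1 to compound 2 and a 3.2-fold higher number (0.50 log units; beyond the scatter) from compound 3 to compound 4, 1.1-fold (0.04 log units) apart, within the scatter of two such steps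

The exchange replaces one fluorine with two chlorines and also moves the halogens around the ring, so these compounds leave open whether the kind, the number or the placing of the halogens sets the size of the step. On these data alone, an unsubstituted phenyl on the same chain carbon would be a useful point of comparison, and how an amine or a carboxylic acid on that ring would read in this assay also remains open.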